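From 4-methylphenyl to 3-fluorophenyl: compound 2 to compound 4

The compounds below may be only part of what the source reports. "The series", "measured", "known", "first", "only" and "open" are said of these compounds alone.

Measured in an ADME assay on HUVEC cells (Homo sapiens) for cytotoxicity, read by MTT assay, with a stated time of 24 h; a lower number here means that less compound is tolerated, a higher number that more compound is tolerated:
compound 1 `O=[N+]([O-])c1ccccc1/C=C/c1nnc(-c2ccc3c(c2)OCCO3)o1` gives 323000 nM
compound 2 `Cc1ccc(/C=C/c2nnc(-c3ccc4c(c3)OCCO4)o2)cc1` gives 265000 nM
compound 3 `Fc1ccccc1/C=C/c1nnc(-c2ccc3c(c2)OCCO3)o1` gives 402000 nM

Compound 2 lies within the scatter of both other compounds, so these numbers set no order among them. Compound 4 `Fc1cccc(/C=C/c2nnc(-c3ccc4c(c3)OCCO4)o2)c1` is still unmeasured and differs from compound 2 as follows: 3-fluorophenyl in place of 4-methylphenyl on a double-bonded chain carbon bound to a double-bonded chain carbon, with 3-fluorophenyl in place of 4-methylphenyl on a double-bonded chain carbon bound to a double-bonded chain carbon.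

Among the compounds with values here, two measured steps bear on this change. One is a 1.5-fold higher number from compound 2 to compound 3 (0.18 log units; within the scatter), where 2-fluorophenyl replaces 4-methylphenyl. The other is a 1.2-fold higher number from compound 1 to compound 3 (0.10 log units; within the scatter), where fluoro replaces nitro. Both lie within the scatter, so no step beyond it is expected in this assay. The expected change is small, an estimated 1.3-fold higher number from compound 2 to compound 4 (0.11 log units; within the scatter). The estimate for compound 4 is 340000 nM, with an expected range from 210000 nM to 520000 nM.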

Compound 4, half-maximal cytotoxic concentration: 295000 nM
Estimate against measurement, compound 4: 1.2-fold (0.06 log units) above; the range from low to high includes it.
By their numbers in this assay, from the lowest: compounds 2, 4, 1 and 3 (each within the scatter of the next).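

In this assay 3-fluorophenyl in place of 4-methylphenyl on a double-bonded chain carbon gives a 1.1-fold higher number from compound 2 to compound 4 (0.05 log units; within the scatter) and 3-fluorophenyl in place of 2-fluorophenyl at that same carbon gives a 1.4-fold lower number from compound 3 to compound 4 (0.13 log units; within the scatter). Both steps lie within the scatter, so these numbers set no order among 4-methylphenyl, 2-fluorophenyl and 3-fluorophenyl at this position. No measurement at hand offers an explanation for these numbers. Still open, as far as these compounds go, is whether an amine or a carboxylic acid at this chain carbon would give a step beyond the scatter in this assay.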